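The source may report more compounds than this note shows. Statements on the series, on what has been measured and on what is new or still open speak of the compounds shown alone.

Measured so far in a functional assay on PC-3 cells (Homo sapiens) for inhibition, read by sulforhodamine B assay, with a stated time of 48 h; a lower number here means a stronger inhibitor of growth, a higher number a weaker inhibitor of growth:
compound 1 `COc1ccc(/C=N/NC(=S)NC(C)(C)[C@H]2CC=C(C)CC2)cc1`: 1200 nM
compound 2 `CC1=CC[C@H](C(C)(C)NC(=S)N/N=C/c2cccc(Cl)c2)CC1`: 6600 nM

Among the measured compounds shown here, compound 2 has the higher of the two numbers in this assay; the only measured step is a 5.5-fold higher number from compound 1 to compound 2 (0.74 log units; beyond the scatter). Compound 3 `CC1=CC[C@H](C(C)(C)NC(=S)N/N=C/c2cccs2)CC1` differs from compound 2 by thiophen-2-yl in place of 3-chlorophenyl on a carbon with a double bond to nitrogen. For the measured compounds named here, the measured step bears on this change only in that it too exchanges the group on the carbon with a double bond to nitrogen; no measured pair exchanges that group for a thiophen-2-yl, so the numbers give no direction. Compound 3 is therefore expected close to compound 2, with an estimated step of a 1.5-fold lower number from compound 2 to compound 3 (0.17 log units; within the scatter) in this assay and an estimate of 4500 nM (range 1500 nM to 14000 nM).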

Compound 3, concentration for total growth inhibition: 62800 nM
Beside the measured number, compound 3's estimate is 14-fold (1.14 log units) below it; measured number outside the range, above it.
By their numbers in this assay, from the lowest: compound 1; then compound 2; then compound 3.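

In this assay, the group on the carbon with a double bond to nitrogen controls more of the range than the first step suggested: thiophen-2-yl gives a 9.5-fold higher number from compound 2 to compound 3 (0.98 log units; beyond the scatter) and a 52-fold higher number from compound 1 to compound 3 (1.72 log units; beyond the scatter) in the same sentence of the series. Compound 3 is thus the weakest inhibitor of growth of the three, with both phenyl groups ahead of thiophen-2-yl at this place. No measurement at hand accounts for the size of these steps.
Still open, from the compounds shown here alone, is how a furan-2-yl or an unsubstituted phenyl would compare at this place. Also open, going by these compounds, is whether an amine or a carboxylic acid on the ring would move the number in either direction.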